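Amide-nitrogen substituents and solubility: compound 2 to compound 3

A few compounds are considered here, and "the series" means these few. Any claim that something is new, unique, unknown or untested is made for them only; others in the source may bear on it.

Measured so far in a physicochemical assay for solubility, read by chemiluminescence; on this read-out lower numbers stand for lower solubility and higher numbers for higher solubility:
- compound 1 `O=C(CN(C(=O)c1ccc(-c2ccccn2)cc1)C1CCCOC1)Nc1cc(F)cc(F)c1` gives 56 ug/mL
- compound 2 `O=C(CN(CC1CCC1)C(=O)c1ccc(-c2ccccn2)cc1)Nc1cc(F)cc(F)c1` gives 7 ug/mL

Among the measured compounds shown here, compound 2 holds the lower of the two numbers, and compound 1 is its only neighbour. Compound 3 `COCC(C)N(CC(=O)Nc1cc(F)cc(F)c1)C(=O)c1ccc(-c2ccccn2)cc1` is not yet measured. Its difference from compound 2 reads 1-(methoxymethyl)ethyl in place of cyclobutylmethyl on an amide-type nitrogen and puts 1-(methoxymethyl)ethyl in place of cyclobutylmethyl on an amide-type nitrogen. For the measured compounds named here, one measured step bears on this, an 8.0-fold lower number from compound 1 to compound 2 (0.90 log units; beyond the scatter) with cyclobutylmethyl in place of oxan-3-yl at that nitrogen. The entering group, like the oxan-3-yl of compound 1, carries oxygen, so a partial reversal of that modest step is expected, towards a higher number in this assay and beyond the scatter. A single step is thin support. The expected step is a 5.0-fold higher number from compound 2 to compound 3 (0.70 log units; beyond the scatter) by this estimate. For compound 3 the estimate is 35 ug/mL with an expected range from 14 ug/mL to 85 ug/mL on this read-out.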

Compound 3, solubility: 58 ug/mL
The estimate for compound 3 lay 1.7-fold (0.22 log units) below the measured number, and the stated range covers the measured number.
By their numbers in this assay, from the lowest: compound 2; then compounds 1 and 3 (each within the scatter of the next).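

In this assay, 1-(methoxymethyl)ethyl at the amide-type nitrogen gives an 8.3-fold higher number from compound 2 to compound 3 (0.92 log units; beyond the scatter) and, set against oxan-3-yl, gives a 1.0-fold higher number from compound 1 to compound 3 (0.02 log units; within the scatter) on the same read-out. A ring at this nitrogen is therefore not needed for the higher number: the two oxygen-carrying groups, one with a ring and one without, read alike, and among these three compounds only the carbon-only cyclobutylmethyl of compound 2 stands lower. No measurement at hand accounts for this difference.

The compounds shown leave open whether a carbon-only open chain such as isobutyl would read with compound 2 or with compound 1 and compound 3, which would separate the oxygen from the loss of the carbon ring. On these data alone, how an amine or a carboxylic acid at this nitrogen would read also remains open.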